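Ether aryl exchange on a shared-core series

The compounds below may be only part of what the source reports. "The series", "measured", "known", "first", "only" and "open" are said of these compounds alone.

Compound 1 `Cn1c(C2CC2)nc2ccc(-n3ccc(OCc4ccc(F)cc4)cc3=O)cc21` is measured in an assay on CHO cells for displacement of a labelled ligand from melanin-concentrating hormone receptor 1 (Rattus norvegicus), read by scintillation counting, with a stated time of 1 h (on this read-out higher numbers stand for weaker inhibition and lower numbers for stronger inhibition), where compound 1 gives 28 nM. Compound 2 `Cn1c(CC2CC2)nc2ccc(-n3ccc(OCc4ccc(F)cc4)cc3=O)cc21` differs from it by cyclopropylmethyl in place of cyclopropyl on an aromatic carbon; in this assay compound 2 gives 140 nM, and the step is a 5.0-fold higher number from compound 1 to compound 2 (0.70 log units; beyond the scatter). Of the two numbers shown, compound 1 has the lowest, with compound 2 as its only neighbour. Compound 3 `Cn1c(C2CC2)nc2ccc(-n3ccc(OCc4ccc(Cl)s4)cc3=O)cc21` carries the change (5-chlorothiophen-2-yl in place of 4-fluorophenyl on a saturated chain carbon bound to an oxygen on an aromatic ring). Within the data shown here, the one measured step, a 5.0-fold higher number from compound 1 to compound 2 (0.70 log units; beyond the scatter), concerns the group on the aromatic carbon of the shared core and does not touch the ether aryl group, so nothing measured bears directly on this change. No step beyond the scatter is therefore expected in this assay; the expected step is a 1.3-fold higher number from compound 1 to compound 3 (0.10 log units; within the scatter). Compound 3 is estimated at 35 nM, with a range from 12 nM to 110 nM.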

Compound 3, half-maximal inhibitory concentration: 11 nM
The estimate for compound 3 lay 3.2-fold (0.50 log units) above the measured number; measured number outside the range, below it.
By their numbers in this assay, from the lowest: compound 3; then compound 1; then compound 2.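

The ether aryl group is a position that moves the number in this assay: 5-chlorothiophen-2-yl in place of 4-fluorophenyl gives a 2.5-fold lower number from compound 1 to compound 3 (0.41 log units; beyond the scatter), whereas the earlier pair varied only the group on the aromatic carbon of the shared core. This single change replaces a six-membered aromatic ring of carbon only with a five-membered aromatic ring with 1 hetero atom, and fluorine with chlorine, so ring and halogen change together. Nothing on hand accounts for the direction or size of this step.

Still open, going by these compounds, is whether the ring or the halogen carries the step, which 4-chlorophenyl or 5-fluorothiophen-2-yl would separate. Also open, on these data alone, are whether the step holds with cyclopropylmethyl on the core, as in compound 2, and how an amine or a carboxylic acid on the ether aryl ring would read.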